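Positional isomer of compound 1: pyridin-4-yl for pyridin-2-yl

The source may hold more compounds than are shown below. What is called first, only, known or untested is meant among the compounds shown, and "the series" means these compounds.

Measured so far:
Compound 1 `CCN(Cc1ccccn1)c1ccc(C(=O)N2CCc3ccc(OS(N)(=O)=O)cc3C2)cc1`: 87.7%
Compound 2 `CN(CCN1CCCCC1)c1cccc(C(=O)N2CCc3ccc(OS(N)(=O)=O)cc3C2)c1`: 30.8%
Compound 3 `CCN(Cc1ccc(Br)cc1)c1cccc(C(=O)N2CCc3ccc(OS(N)(=O)=O)cc3C2)c1`: 84.5%

In an assay on HEK293 cells for inhibition of Steryl-sulfatase (Homo sapiens), tested at 1 uM (on this read-out lower numbers stand for a weaker effect and higher numbers for a stronger effect at the one concentration tested), compound 1 stands highest of the three numbers; compound 3 sits within the scatter of it, while compound 2 lies far lower. Among the compounds with values here, the only measured step is a number 53.7 percentage points higher from compound 2 to compound 3 (beyond the scatter), which concerns a different amine substituent on the shared core and does not bear directly on the change examined here. Compound 4 `CCN(Cc1ccncc1)c1ccc(C(=O)N2CCc3ccc(OS(N)(=O)=O)cc3C2)cc1` differs from compound 1 by pyridin-4-yl in place of pyridin-2-yl on a saturated chain carbon bound to a nitrogen on an aromatic ring. Within the data shown here, no measured pair tests this shift of the ring nitrogen. The expected step is a number 5.7 percentage points lower from compound 1 to compound 4 (within the scatter), not beyond the scatter. Compound 4 is therefore estimated at 82%, with a range from 62% to 93%.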

Compound 4, a percentage reported as inhibition, at one concentration (the size of the read-out at that concentration, not a potency): 86.6%
Estimate against measurement, compound 4: 4.6 percentage points below; the measured number falls inside the stated range.
By their numbers in this assay, from the lowest: compound 2; then compounds 3, 4 and 1 (each within the scatter of the next).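

In this assay, the change from pyridin-2-yl to pyridin-4-yl on a saturated chain carbon bound to a nitrogen on an aromatic ring gives a number 1.1 percentage points lower from compound 1 to compound 4 (within the scatter) at the one concentration tested. Within the data shown here, this pair is the first to test the ring nitrogen's location alone, and the read-out does not separate the two isomers. No evidence on hand bears on this result.

Open questions are whether pyridin-3-yl at this place reads the same, and whether a carboxylic acid on the pyridine ring would leave the read-out unchanged.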